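Methoxy to ethoxy at the limit of the assay

The compounds below may be only part of what the source reports. "The series", "measured", "known", "first", "only" and "open" are said of these compounds alone.

Compound 1 `COc1ccc(-c2ncnn2-c2cc(OC)c(OC)c(OC)c2)cc1`: 50 nM
Compound 2 `COc1cccc(-c2ncnn2-c2cc(OC)c(OC)c(OC)c2)c1`: > 10000 nM

Both compounds were tested in a functional assay on Jurkat cells (Homo sapiens) for antiproliferative activity, read by MTT assay, with a stated time of 72 h; on this read-out higher numbers stand for weaker inhibition and lower numbers for stronger inhibition. Compound 2 gives > 10000 nM, and this value is a limit, not a number. It stands at the end of the scale: the limit of > 10000 nM in this assay, at which 1 of the 2 values shown sits.

Compound 3 `CCOc1cccc(-c2ncnn2-c2cc(OC)c(OC)c(OC)c2)c1` differs from compound 2 in one place: methyl in place of hydrogen on a saturated chain carbon bound to an oxygen on an aromatic ring. In words, methyl replaces hydrogen on a saturated chain carbon bound to an oxygen on an aromatic ring, turning methoxy into ethoxy.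

Among the compounds with values here, only one measured step bears on this, and only indirectly. The step of an at least 200-fold higher number from compound 1 to compound 2 (2.30 log units; beyond the scatter) is large and shows that a change to this aryl group can cost nearly all activity in this assay. Within the data shown here, it does not measure chain lengthening, and no measured compound shows such a change restoring activity. Compound 3 is therefore expected to stay at or close to the limit of compound 2, with no clear step in either direction. The expected change is an at least 1.1-fold lower number from compound 2 to compound 3 (0.04 log units; that floor lies within the scatter). For compound 3 the estimate is 9000 nM, with an expected range from 2000 nM to 20000 nM.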

Compound 3, half-maximal inhibitory concentration: > 10000 nM
Compound 3: no number, only a limit; the forecaster's own chance of this, stated with the estimate: 70%; at least 1.1-fold (0.04 log units) between middle value and limit.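

In this assay compound 3 gives > 10000 nM as a limit, not a number. Compound 2 also stands at a limit, so no step from compound 2 to compound 3 can be read, and both sit at the end of the scale: the limit of > 10000 nM in this assay, at which 2 of the 3 values shown sit.
The compounds shown leave open whether methoxy and ethoxy in this place differ at all in how strongly they inhibit.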